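Swapping bromo for ethylamino on the side chain

The source may report more compounds than this note shows. Statements on the series, on what has been measured and on what is new or still open speak of the compounds shown alone.

Results so far in a functional assay on HCT-8 cells (Homo sapiens) for antiproliferative activity, read by MTT assay, with a stated time of 48 h (a lower number here means a stronger inhibitor, a higher number a weaker inhibitor), are these:
- compound 1 `COc1ccc(C(=O)c2ccc(OC)c3c2C=CC(C)(C)O3)c(NC(=O)CBr)c1` gives 4360 nM
- compound 2 `COc1ccc(C(=O)c2ccc(OC)c3c2OC(C)(C)C=C3)c(NC(=O)CO)c1` gives 230 nM
- compound 3 `CCNCC(=O)Nc1cc(OC)ccc1C(=O)c1ccc(OC)c2c1OC(C)(C)C=C2` gives 3690 nM

Compound 1 sits at the weak end of this small set, level within the scatter with compound 3 and at a clearly higher number than compound 2. Compound 4 `CCNCC(=O)Nc1cc(OC)ccc1C(=O)c1ccc(OC)c2c1C=CC(C)(C)O2` keeps the core of compound 1 and changes one group. The change is ethylamino in place of bromo on a saturated chain carbon bound to a carbonyl carbon and reads as ethylamino in place of bromo on a saturated chain carbon bound to a carbonyl carbon.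

Among the measured compounds shown here, the one measured step bringing in this group is a 16-fold higher number from compound 2 to compound 3 (1.21 log units; beyond the scatter) and it is large. However, it starts from hydroxy rather than bromo, on a core arranged differently from that of compound 1. For the measured compounds named here, no pair of compounds isolates the core arrangement alone. Compound 3 at 3690 nM carries the side chain that compound 4 will have, so little movement is expected. The expected step is a 1.2-fold lower number from compound 1 to compound 4 (0.10 log units; within the scatter) and nothing beyond the scatter is anticipated. For compound 4 the estimate is 3500 nM with an expected range from 1200 nM to 10000 nM in this measurement.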

Compound 4, half-maximal inhibitory concentration: 7890 nM
Estimate against measurement, compound 4: 2.3-fold (0.35 log units) below; low and high end bracket the measured number.
By their numbers in this assay, from the lowest: compound 2; then compounds 3, 1 and 4 (each within the scatter of the next, the first and the last beyond it).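

In this assay the change gives a 1.8-fold higher number from compound 1 to compound 4 (0.26 log units; within the scatter), so on the core of compound 1, bromo and ethylamino on this saturated chain carbon cannot be told apart. The earlier compounds shown here showed ethylamino only against hydroxy, on a differently arranged core, as a 16-fold higher number from compound 2 to compound 3 (1.21 log units; beyond the scatter); this new pair sets it against bromo, and the large step seen there has no counterpart here. Nothing available explains why these two groups read alike.

Among the compounds shown here, still open is whether hydroxy on the core of compound 1 would reach a number close to that of compound 2 at 230 nM, and no pair isolates the arrangement of the core. Going by these compounds, how a carboxylic acid or a longer amine chain would read on this same carbon also remains unknown.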